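The compounds below may be only part of what the source reports. "The series", "measured", "known", "first", "only" and "open" are said of these compounds alone.

Three compounds built on a shared core were tested in a functional assay on K562 cells (Homo sapiens), read by MTT assay, with a stated time of 72 h; on this read-out lower numbers stand for stronger inhibition and higher numbers for weaker inhibition. Compound 2 `CSc1ncnc2c1c(-c1ccoc1)cn2[C@@H]1O[C@H](CO)[C@@H](O)[C@H]1O` gives 3250 nM. Compound 1 `CN(C)c1ncnc2c1c(-c1ccoc1)cn2[C@@H]1O[C@H](CO)[C@@H](O)[C@H]1O` gives 14900 nM. For compound 3 `CSc1ncnc2c1c(-c1cccs1)cn2[C@@H]1O[C@H](CO)[C@@H](O)[C@H]1O` the result is not a number but a limit of the assay, > 20000 nM, and that is the limit of > 20000 nM in this assay, at which 1 of the 3 values shown sits.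

The change from compound 2 to compound 1 is dimethylamino in place of methylsulfanyl on an aromatic carbon, and it made a 4.6-fold higher number from compound 2 to compound 1 (0.66 log units; beyond the scatter). The cores of compound 2 and compound 3 differ by thiophen-2-yl in place of furan-3-yl on an aromatic carbon, and this made an at least 6.1-fold higher number from compound 2 to compound 3 (0.78 log units; beyond the scatter).

Compound 4 `CN(C)c1ncnc2c1c(-c1cccs1)cn2[C@@H]1O[C@H](CO)[C@@H](O)[C@H]1O` has not yet been measured in this assay. It differs from compound 3 by dimethylamino in place of methylsulfanyl on an aromatic carbon, the same change as from compound 2 to compound 1, made at a place described in the same words. In the earlier instance the step was a 4.6-fold higher number from compound 2 to compound 1 (0.66 log units; beyond the scatter), a weakening. Compound 3 already sits at a limit. The step from compound 3 to compound 4 is therefore expected to be about a step that the limit leaves unreadable from compound 3 to compound 4. Compound 4 is estimated at 60000 nM, between 20000 nM and 200000 nM, most probably reported again only as a limit.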

Compound 4, half-maximal inhibitory concentration: > 20000 nM
Compound 4 ended at the assay's limit; the forecaster's own chance of this, stated with the estimate: 85%; the middle value does not contradict the limit.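

In this assay, on these data alone, compound 3 and compound 4 both ended at a limit of the assay rather than at a number, so the step from methylsulfanyl to dimethylamino cannot be read on the core carrying thiophen-2-yl, and whether the weakening seen with furan-3-yl carries over stays untested. The reverse comparison, thiophen-2-yl in place of furan-3-yl with dimethylamino present, can be read only as a floor: it is an at least 1.3-fold higher number from compound 1 to compound 4 (0.12 log units; that floor lies within the scatter), which by itself does not establish a real weakening on this core. Set beside the same change with methylsulfanyl present, this neither confirms nor rules out that the change carries across cores with a similar size: the same change on two cores in this assay, an at least 6.1-fold higher number (0.78 log units; beyond the scatter) from compound 2 to compound 3 and an at least 1.3-fold higher number (0.12 log units; that floor lies within the scatter) from compound 1 to compound 4; the limit leaves it open whether they differ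

As far as these compounds go, the true size of either change on the thiophen-2-yl core remains open, as no number exists for that pair. Also open, from the compounds shown here alone, is how a plain amino group or a methoxy group in place of methylsulfanyl, or a phenyl ring in place of furan-3-yl, would read in this assay.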